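The source may hold more compounds than are shown below. What is called first, only, known or untested is meant among the compounds shown, and "the series" means these compounds.

Of the compounds shown here, three sharing one core have been measured in an assay on isolated protein for inhibition of histamine H2 receptor (Cavia porcellus); on this read-out lower numbers stand for tighter binding and higher numbers for weaker binding. Compound 1 `COc1ccc(N/C(S)=N/CCCOc2cccc(CN3CCCCC3)c2)cc1` gives 4370 nM, compound 2 `O=C(NCCCOc1cccc(CN2CCCCC2)c1)NCc1ccccc1` gives 347 nM, and compound 3 `CC(C)CNC(=O)NCCCOc1cccc(CN2CCCCC2)c1` gives 170 nM. Compound 2 thus stands second highest of the three numbers, with compound 3 nearest to it and compound 1 furthest away. Compound 4 `CC(C)(C)NC(=O)NCCCOc1cccc(CN2CCCCC2)c1` differs from compound 2 in one place: tert-butyl in place of benzyl on an amide-type nitrogen. Among the compounds with values here, the only measured step that bears on this exchange is a 2.0-fold lower number from compound 2 to compound 3 (0.31 log units; beyond the scatter), a modest shift in which the benzyl was likewise replaced by a small saturated group. A step of similar size and direction is expected here. Compound 4 is therefore estimated at 200 nM, with a range from 70 nM to 600 nM. For compound 4 this expectation amounts to a 1.7-fold lower number from compound 2 to compound 4 (0.24 log units; within the scatter).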

Compound 4, dissociation constant: 2090 nM
Compound 4: the middle estimate sits 10-fold (1.02 log units) below what was measured; the whole stated range lies below it.
By their numbers in this assay, from the lowest: compound 3; then compound 2; then compound 4; then compound 1.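

Exchanging benzyl for tert-butyl on this amide-type nitrogen gives a 6.0-fold higher number from compound 2 to compound 4 (0.78 log units; beyond the scatter), the opposite direction to the step seen with isobutyl. Between the two saturated groups the gap is wider still, with a 12-fold higher number from compound 3 to compound 4 (1.09 log units; beyond the scatter), so a small saturated group on this nitrogen does not by itself set the direction of the change. Nothing available accounts for this difference between isobutyl and tert-butyl. The compounds shown leave open where a straight butyl chain or a cyclohexylmethyl group on this nitrogen would fall.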